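Isopropyl for methoxycarbonyl on the core of compound 1

A few compounds are considered here, and "the series" means these few. Any claim that something is new, unique, unknown or untested is made for them only; others in the source may bear on it.

Compound 1 `COC(=O)c1cccc2c1nc(-c1c(F)cccc1F)n2Cc1c(F)cccc1F` gives 57.7 uM in a toxicity assay on CCRF-CEM cells (Homo sapiens) for cytotoxicity (on this read-out higher numbers stand for lower toxicity in this test and lower numbers for higher toxicity in this test), the highest of the two numbers in the set. Compound 2 `CNc1cccc2c1nc(-c1c(F)cccc1F)n2Cc1c(F)cccc1F` gives 27.2 uM, and the change is a 2.1-fold lower number from compound 1 to compound 2 (0.33 log units; beyond the scatter). Compound 3 `CN(C)c1cccc2c1nc(-c1c(F)cccc1F)n2Cc1c(F)cccc1F` reaches only the assay limit > 100 uM. Against compound 1 this is an at least 1.7-fold higher number from compound 1 to compound 3 (0.23 log units; that floor lies within the scatter), and against compound 2 it is an at least 3.6-fold higher number from compound 2 to compound 3 (0.56 log units; beyond the scatter); the limit itself is the limit of > 100 uM in this assay, at which 1 of the 3 values shown sits. Compound 4 `CC(C)c1cccc2c1nc(-c1c(F)cccc1F)n2Cc1c(F)cccc1F` carries isopropyl in place of methoxycarbonyl on an aromatic carbon. For the measured compounds named here, no measured step introduces isopropyl; the two replacements of methoxycarbonyl moved the number in opposite directions and by modest amounts at most, so in this assay a step within the scatter, at most modest in either direction, is expected. Compound 4 is estimated at 55 uM, between 22 uM and 130 uM, which would mean an expected 1.0-fold lower number from compound 1 to compound 4 (0.02 log units; within the scatter).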

Compound 4, half-maximal toxic concentration: 27 uM
The estimate for compound 4 lay 2.0-fold (0.31 log units) above the measured number, and the stated range covers the measured number.
By their numbers in this assay, from the lowest: compounds 4 and 2 (each within the scatter of the next); then compound 1. At a limit, above all of these: compound 3.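

In this assay, the all-carbon isopropyl gives a 2.1-fold lower number from compound 1 to compound 4 (0.33 log units; beyond the scatter), the same direction as methylamino, so this position does not need a nitrogen-bearing group to reach the lower number. Against methylamino the change is a 1.0-fold lower number from compound 2 to compound 4 (0.00 log units; within the scatter), leaving compound 2 and compound 4 indistinguishable, while dimethylamino remains the outlier, with an at least 3.7-fold lower number from compound 3 to compound 4 (0.56 log units; beyond the scatter). The value of compound 3 is a limit, not a number: the limit of > 100 uM in this assay, at which 1 of the 4 values shown sits.

A carboxylic acid, a primary amine or a longer chain on this aromatic carbon could either stay with compound 2 and compound 4 or approach compound 3. Going by these compounds, whether that separation belongs to dimethylamino alone remains open.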